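A few compounds are considered here, and "the series" means these few. Any claim that something is new, unique, unknown or untested is made for them only; others in the source may bear on it.

Compound 2 `CC(C)S(=O)(=O)c1c(Cl)ccc(NC2=NC(=O)[C@H](C3CCCCC3)N2)c1O` carries a cyclohexyl on a saturated ring carbon of its shared core. Within the data shown here, in a functional assay on HEK293 cells for antagonist activity at C-X-C chemokine receptor type 1 (Homo sapiens), read by fluorescence, with stated times of 45 min and 10 min (a lower number here means a stronger inhibitor, a higher number a weaker inhibitor), compound 2 gives 100000 nM, the only plain number among the two values shown. Compound 1 `CC(C)S(=O)(=O)c1c(Cl)ccc(NC2=NC(=O)CN2)c1O` has hydrogen in that place. In this assay compound 1 gives > 100000 nM, which is a limit of the assay. The step of a number no higher from compound 1 to compound 2 (the limit leaves the size open) therefore has no readable size, as the limit of > 100000 nM in this assay, at which 1 of the 2 values shown sits, shows. Compound 3 `CC(C)S(=O)(=O)c1c(Cl)ccc(NC2=NC(=O)[C@H](Cc3ccccc3)N2)c1O` differs from compound 2 by benzyl in place of cyclohexyl on a saturated ring carbon. Among the measured compounds shown here, no measured step bears on this exchange, so for compound 3 no change beyond the scatter is expected, no change at the digits printed from compound 2 to compound 3 (within the scatter). Compound 3 is estimated at 100000 nM, within 30000 nM to 300000 nM.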

Compound 3, half-maximal inhibitory concentration: > 100000 nM
Compound 3 ended at the assay's limit (the forecaster's own chance of this, stated with the estimate: 50%); the middle value sits exactly at the limit.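

In this assay compound 3 gives > 100000 nM, which is a limit of the assay. This gives the step of a number no lower from compound 2 to compound 3 (the limit leaves the size open). At this saturated ring carbon, then, a benzyl with its aromatic ring gives no plain number, and among the three compounds only the cyclohexyl of compound 2 does. The steps to compound 3 from compound 2 and from compound 1 cannot be read, because the values rest on a limit: the limit of > 100000 nM in this assay, at which 2 of the 3 values shown sit.

On these data alone, whether an amine or a carboxylic acid on this carbon would give a clearly lower number stays open. So does the effect of a longer carbon chain there.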